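Cytotoxicity limits and the step to compound 4

The source may hold more compounds than are shown below. What is called first, only, known or untested is meant among the compounds shown, and "the series" means these compounds.

Measured compounds in an ADME assay on cells (Peritoneal macrophage cell, Mus musculus) for cytotoxicity, read by fluorescence and resazurin assay, with a stated time of 3 days (on this read-out higher numbers stand for lower toxicity in this test and lower numbers for higher toxicity in this test), every value a limit of the assay:
- compound 1 `COc1ccc(C(=O)Nc2cc(-c3ccccn3)n[nH]2)cc1` gives > 40300 nM
- compound 2 `N#Cc1ccc(OC2CCN(C(=O)Nc3cc(-c4ccccn4)n[nH]3)CC2)cc1` gives > 64000 nM
- compound 3 `O=C(NCc1cccc(Cl)c1)Nc1cc(-c2ccccn2)n[nH]1` gives > 64000 nM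

In this assay compound 2 gives > 64000 nM and this is a limit, not a number. Compound 2 lies at the limit of > 64000 nM in this assay, at which 2 of the 3 values shown sit, and so has no number to rank against the others. Compound 1 stands at the limit of > 40300 nM in this assay, at which 1 of the 3 values shown sits, and this too is only a limit.

Compound 4 `O=C(Nc1cc(-c2ccccn2)n[nH]1)N1CCC(c2ccc(Cl)cc2)CC1` is still unmeasured. It differs from compound 2 with 4-chlorophenyl in place of 4-cyanophenoxy on a saturated ring carbon, three ring bonds from the ring nitrogen, as counted here: 4-chlorophenyl in place of 4-cyanophenoxy on a saturated ring carbon and the rest of the structure stays the same.

Among the compounds with values here, no measured pair shows this change. The expectation leans on compound 3, whose > 64000 nM is also a limit. The expected step of an at least 1.4-fold lower number from compound 2 to compound 4 (0.15 log units; that floor lies within the scatter) is an estimate and is expected to stay within the usual scatter, and another limit reading would be no surprise. Compound 4 is estimated at 45000 nM with a range from 15000 nM to 64000 nM expected in this assay once it is read.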

Compound 4, half-maximal cytotoxic concentration: > 55000 nM
Compound 4: no number, only a limit; the forecaster's own chance of this, stated with the estimate: 55%; middle value at least 1.2-fold (0.08 log units) away from the limit.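

In this assay, within the data shown here, compound 2 and compound 4 both read only as limits, and no step between the two can be read. The compounds shown leave open where any of them would reach a half-maximal cytotoxic concentration, and whether 4-chlorophenyl and 4-cyanophenoxy differ at all on this read-out.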